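Alkyl on the ring amine nitrogen: compound 3 neopentyl

The source may report more compounds than this note shows. Statements on the series, on what has been measured and on what is new or still open speak of the compounds shown alone.

Measured so far:
compound 1 `CCN1CC[C@H](NC(=O)C[C@@H]2C(=O)NC=CN2S(=O)(=O)c2ccc(C)cc2)C(C)(C)C1` with 0.63 nM
compound 2 `Cc1ccc(S(=O)(=O)N2C=CNC(=O)[C@H]2CC(=O)N[C@H]2CCN(CC(C)C)CC2(C)C)cc1` with 0.86 nM

Both were run in an in vitro functional assay on cells for antagonist activity at B1 bradykinin receptor (Homo sapiens), read by luminescence and calcium flux, with a stated time of 2 h; on this read-out higher numbers stand for weaker inhibition and lower numbers for stronger inhibition. Compound 2 holds the higher of the two numbers, but the gap between them is a 1.4-fold higher number from compound 1 to compound 2 (0.14 log units; within the scatter), so the two cannot be ordered.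

Compound 3 `Cc1ccc(S(=O)(=O)N2C=CNC(=O)[C@H]2CC(=O)N[C@H]2CCN(CC(C)(C)C)CC2(C)C)cc1` differs from compound 2 in one place: methyl in place of hydrogen on a saturated chain carbon bound to three saturated chain carbons. Cut one bond further out, this reads isopropyl to tert-butyl, or isobutyl to neopentyl, on the chain carried by the ring amine nitrogen.

Going by the values given here, only one measured step bears on it, the change of that same chain, and it was a 1.4-fold higher number from compound 1 to compound 2 (0.14 log units; within the scatter). On that basis no step beyond the scatter is expected for compound 3, with at most a small drift toward a higher number, a 1.4-fold higher number from compound 2 to compound 3 (0.14 log units; within the scatter).

Compound 3 is therefore estimated at 1.2 nM in this assay, with a range of 0.4 nM to 4 nM.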

Compound 3, half-maximal inhibitory concentration: 1.38 nM
Compound 3: the middle estimate sits 1.2-fold (0.06 log units) below what was measured; low and high end bracket the measured number.
By their numbers in this assay, from the lowest: compounds 1, 2 and 3 (each within the scatter of the next, the first and the last beyond it).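

Methyl in place of hydrogen on a saturated chain carbon bound to three saturated chain carbons, which reads isobutyl to neopentyl, gives a step within the scatter in this assay (a 1.6-fold higher number from compound 2 to compound 3 (0.21 log units; within the scatter)), so this single addition cannot be told from no change. Tert-butyl in place of methyl on a saturated chain carbon bound to an amine nitrogen in a ring gives the first step in the series beyond the scatter (a 2.2-fold higher number from compound 1 to compound 3 (0.34 log units; beyond the scatter)), and it is modest, so the number moves only slightly across the whole range of chains shown. No measurement at hand accounts for this step.

Open, as far as these compounds go, is how this position responds to a longer straight chain, such as n-hexyl, or to a cyclopropylmethyl group. From the compounds shown here alone, a chain carrying a hydroxyl group or an ether oxygen, and a bare hydrogen on the same nitrogen, also remain open.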